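This account rests on a few compounds, and the source may have more. Where it says the series, first, only, none or still open, it means among the compounds named here.

Working notes on the series.

Of the compounds shown here, three that share one core have been measured. Compound 1 `Clc1cccc(Nc2ccc(N3CC4CC(C3)N4)cn2)c1` gives 4.8 nM in an assay on HEK293 cells for displacement of a labelled ligand from Neuronal acetylcholine receptor; alpha3/beta4 (Homo sapiens); a higher number here means a weaker inhibitor, a lower number a stronger inhibitor. Compound 2 `Oc1ccc(Nc2ccc(N3CC4CC(C3)N4)cn2)cc1` gives 165 nM in this assay, and compound 3 `COc1ccc(Nc2ccc(N3CC4CC(C3)N4)cn2)cc1` gives 9.03 nM. Compound 1 has the lowest number of the three: the nearest is compound 3, whose value lies within the scatter of that of compound 1, while compound 2 sits far higher, as the step of a 34-fold higher number from compound 1 to compound 2 (1.54 log units; beyond the scatter) shows. The second step, an 18-fold lower number from compound 2 to compound 3 (1.26 log units; beyond the scatter), is also large and runs the other way.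

Compound 4 `Clc1ccc(Nc2ccc(N3CC4CC(C3)N4)cn2)cc1Cl` differs from compound 1 by a single change: chloro in place of hydrogen on an aromatic carbon. The new chloro sits on an aromatic carbon of the same six-membered aromatic ring of carbon only, ortho to a chloro group and para to a large group. Neither measured step tests this kind of change: one exchanges the whole aryl group, the other methylates an oxygen. Nothing here says that adding a chloro to the 3-chlorophenyl ring of compound 1 should move the number beyond the scatter, so a step of about a 1.1-fold lower number from compound 1 to compound 4 (0.03 log units; within the scatter) is expected, that is, no clear change. Compound 4 is therefore estimated at 4.5 nM, with a range of 1.5 nM to 14 nM.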

Compound 4, inhibition constant: 40.9 nM
Beside the measured number, compound 4's estimate is 9.1-fold (0.96 log units) below it, and the stated range ends below it.
By their numbers in this assay, from the lowest: compounds 1 and 3 (each within the scatter of the next); then compound 4; then compound 2.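

Adding one chloro on an aromatic carbon, ortho to a chloro group and para to a large group, is not a neutral change in this assay: the step of an 8.5-fold higher number from compound 1 to compound 4 (0.93 log units; beyond the scatter) shows that this position of the ring responds to a single added heavy atom. Within the data shown here, the earlier steps exchanged the whole aryl group or methylated an oxygen, so this is the first reading of one new substituent on the 3-chlorophenyl ring of compound 1, and it shows that the number at this position can rise even when the rest of that ring is kept. No measured property or other supporting data accompany these compounds, so the rise stays unexplained.

The compounds shown leave open whether the rise belongs to chloro itself or would also follow from a fluoro, a methyl or a methoxy group at this position. Among these compounds, it is also open whether the existing chloro of compound 1 matters to the outcome, as no compound here carries the new chloro alone on the ring.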